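Selenium in place of tellurium on the shared core

A few compounds are considered here, and "the series" means these few. Any claim that something is new, unique, unknown or untested is made for them only; others in the source may bear on it.

In a functional assay on Jurkat cells (Homo sapiens) for cytotoxicity, read by MTT assay, with a stated time of 24 h (on this read-out lower numbers stand for an effect already at smaller amounts and higher numbers for an effect only at larger amounts of compound), compound 1 `CCOC(=O)c1cc([Se]c2ccccc2)c2cc(Cl)ccc2n1` gives 53000 nM while compound 2 `CCOC(=O)c1cc([Te]c2ccccc2)c2cc(OC)ccc2n1` gives 77400 nM on the same read-out. Among the compounds with values here, these two values lie within the scatter of each other, so compound 2 stands level with the only other measured compound and no order can be drawn between them.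

Compound 3 `CCOC(=O)c1cc([Se]c2ccccc2C)c2cc(OC)ccc2n1` has not yet been measured. Its change from compound 2 is a group of 8 heavy atoms (7 carbon, 1 selenium; one six-membered aromatic ring of carbon only) in place of a group of 7 heavy atoms (6 carbon, 1 tellurium; one six-membered aromatic ring of carbon only), on an aromatic carbon on the aromatic carbon opposite the ring nitrogen. Within the data shown here, no measured pair isolates this exchange, so the data give no direct size for it. Compound 1 also carries selenium, and its 53000 nM lies within the scatter of compound 2 at 77400 nM so no step beyond the scatter is expected in this assay for this change. The expected step is a 1.3-fold lower number from compound 2 to compound 3 (0.11 log units; within the scatter) with no firm direction behind it. Compound 3 is estimated at 60000 nM within an expected range from 25000 nM to 150000 nM on this read-out.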

Compound 3, half-maximal effective concentration: 14900 nM
Compound 3: the middle estimate sits 4.0-fold (0.60 log units) above what was measured; measured number below the stated range.
By their numbers in this assay, from the lowest: compound 3; then compounds 1 and 2 (each within the scatter of the next).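

In this assay, within the data shown here, the place opposite the ring nitrogen now shows a response: the group of 8 heavy atoms (7 carbon, 1 selenium) in place of the group of 7 heavy atoms (6 carbon, 1 tellurium) gives a 5.2-fold lower number from compound 2 to compound 3 (0.72 log units; beyond the scatter), the first step beyond the scatter. Both groups hold one six-membered aromatic ring of carbon only and no hydrogen-bond donors or acceptors, yet the heavy element and the carbon count change together, and this single exchange cannot divide the step between them. Nothing on hand bears on the origin of this step.

The compounds shown leave open how much of the step belongs to selenium and how much to the added carbon, which would take a selenium group and a tellurium group with the same carbon count on the same core. Also open, from the compounds shown here alone, is how this assay responds at this place when the aromatic ring of the group carries an amine or a carboxylic acid, or when a longer chain stands in place of that ring.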